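Swapping the Distal Aryl Ring: From Chlorophenyl to Pyridyl

This account rests on a few compounds, and the source may have more. Where it says the series, first, only, none or still open, it means among the compounds named here.

Measured so far:
Compound 1, `FC(F)(F)c1ccccc1-c1nc(NCc2ccccc2)c2ccccc2n1`, gives 3100 nM in an assay on a protein complex for inhibition of ubiquitin carboxyl-terminal hydrolase 1/WD repeat-containing protein 48 (Homo sapiens), read by fluorescence; on this read-out lower numbers stand for stronger inhibition and higher numbers for weaker inhibition.
Compound 2, `FC(F)(F)c1ccccc1-c1nc(NCc2ccc(-c3cccc(Cl)c3)cc2)c2ccccc2n1`, gives 2700 nM in this assay.

Compound 1 and compound 2 share a core and differ only in that compound 2 carries a 3-chlorophenyl group where compound 1 has hydrogen. The measured step of a 1.1-fold lower number from compound 1 to compound 2 (0.06 log units; within the scatter) shows that this addition did not shift the read-out beyond the scatter, so the two values cannot be told apart.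

Compound 3, `FC(F)(F)c1ccccc1-c1nc(NCc2ccc(-c3ccncc3)cc2)c2ccccc2n1`, has not yet been tested in this assay. It differs from compound 2 by pyridin-4-yl in place of 3-chlorophenyl on an aromatic carbon. For the measured compounds named here, the only measured step that bears on this region, a 1.1-fold lower number from compound 1 to compound 2 (0.06 log units; within the scatter), was flat: attaching the whole 3-chlorophenyl ring changed nothing. Exchanging that ring for pyridin-4-yl is therefore expected to leave the number roughly where compound 2 stands, with the expected step of a 1.1-fold higher number from compound 2 to compound 3 (0.05 log units; within the scatter) lying within the scatter. For compound 3 the estimated value is 3000 nM, expected to fall between 1200 nM and 7500 nM.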

Compound 3, half-maximal inhibitory concentration: 1900 nM
For compound 3 the middle estimate is 1.6-fold (0.20 log units) above the measured one, within the range that was stated.
By their numbers in this assay, from the lowest: compounds 3, 2 and 1 (each within the scatter of the next).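

Replacing 3-chlorophenyl with pyridin-4-yl, which removes the chlorine and adds a ring nitrogen counted as one hydrogen-bond acceptor, gives a 1.4-fold lower number from compound 2 to compound 3 (0.15 log units; within the scatter) in this assay and so leaves compound 2 and compound 3 indistinguishable. Compared with the plain hydrogen, the pyridin-4-yl ring gives a 1.6-fold lower number from compound 1 to compound 3 (0.21 log units; within the scatter) and this too stays inside the usual scatter, so the flat result now holds for two different rings at this position rather than for a single example. No available evidence explains these numbers.

Going by these compounds, whether any group here can move the number beyond the scatter remains open. An amine or a carboxylic acid on the outer ring, or a longer chain in place of that ring, could test this.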